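The source may report more compounds than this note shows. Statements on the series, on what has been measured and on what is new or still open speak of the compounds shown alone.

Measured compounds in a functional assay on MCF7 cells (Homo sapiens) for antiproliferative activity; on this read-out higher numbers stand for weaker inhibition and lower numbers for stronger inhibition:

- compound 1 `CCCCCn1c(Cc2cc(OC)c(OC)c(OC)c2)nc2c(N)nc(F)nc21`: 36300 nM
- compound 2 `CCCCCn1c(Cc2cc(OC)c(OC)c(OC)c2)nc2c(N)ncnc21`: 61700 nM
- compound 3 `CCCCn1c(Cc2cc(OC)c(OC)c(OC)c2Cl)nc2c(N)ncnc21`: 19100 nM

Compound 2 gives the highest of the three numbers in this assay ; compound 1 lies nearest to it, and compound 3 furthest, the gap to compound 3 being beyond the scatter. Going by the values given here, the one single-point step among the measured compounds, a 1.7-fold higher number from compound 1 to compound 2 (0.23 log units; within the scatter), is within the scatter. Compound 3 differs from compound 2 in two places at once, so its lower number cannot be assigned to either change.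

Compound 4 `COc1cc(Cc2nc3c(N)ncnc3n2CC(OC)OC)cc(OC)c1OC` carries the change (dimethoxymethyl in place of butyl on a saturated chain carbon bound to an aromatic nitrogen). Among the compounds with values here, no measured step touches this position or this kind of group, so nothing speaks for a shift in either direction ; the only measured single change, from compound 1 to compound 2, was within the scatter. The step of a 1.0-fold lower number from compound 2 to compound 4 (0.01 log units; within the scatter) is therefore expected to be none beyond the scatter, with the range widened for the absence of a precedent. Compound 4 is estimated at 60000 nM, between 20000 nM and 150000 nM.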

Compound 4, half-maximal inhibitory concentration: 72400 nM
Beside the measured number, compound 4's estimate is 1.2-fold (0.08 log units) below it; the range from low to high includes it.
By their numbers in this assay, from the lowest: compounds 3, 1, 2 and 4 (each within the scatter of the next, the first and the last beyond it).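

In this assay, dimethoxymethyl in place of butyl on a saturated chain carbon bound to an aromatic nitrogen gives a 1.2-fold higher number from compound 2 to compound 4 (0.07 log units; within the scatter). Going by these compounds alone, this is the first step read at this position, and it shows that the chain end can take a group with 2 hydrogen-bond acceptors, in place of one with none, without a change beyond the scatter in this read-out. Nothing available explains the size of this step.

Going by these compounds, whether an amine, a carboxylic acid or a longer chain at this position would shift the number stays open, since a single step here sets no trend. Also open, on these data alone, is whether the same change would read alike on the core of compound 1, which carries fluoro on an aromatic carbon.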